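The compounds below may be only part of what the source reports. "The series", "measured", "known", "first", "only" and "open" are said of these compounds alone.

Series notes, isothiocyanate cyclobutyl ethers. Compound 2 `S=C=N[C@H]1C[C@H](OCc2ccc(-c3ccccc3)cc2)C1` is the weakest of the three measured compounds in an assay on isolated protein for inhibition of N-acylethanolamine-hydrolyzing acid amidase (Homo sapiens), read by fluorescence, with a stated time of 90 min (on this read-out higher numbers stand for weaker inhibition and lower numbers for stronger inhibition), giving 4300 nM. Its ring-inverted counterpart compound 3 `S=C=N[C@H]1C[C@@H](OCc2ccc(-c3ccccc3)cc2)C1` gives 93 nM in this assay, and the biphenyl-substituted compound 1 `CC(C)c1ccc(-c2ccc(CO[C@H]3C[C@@H](N=C=S)C3)c(F)c2)cc1F` gives 227 nM. Going by the values given here, the only single-point step recorded so far is a 46-fold lower number from compound 2 to compound 3 (1.66 log units; beyond the scatter), which rests on the drawn configuration of the saturated ring carbons, as noted in the fact that one of compounds 2 and 3 is drawn with a defined configuration and the other without, at the place where they differ.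

Compound 4 `Cc1ccc(-c2ccc(CO[C@H]3C[C@H](N=C=S)C3)cc2)cc1` keeps the ring configuration of compound 2 and differs from it by methyl in place of hydrogen on an aromatic carbon, placed on an aromatic carbon of a six-membered aromatic ring of carbon only. Among the compounds with values here, no measured step in this set touches a substituent on the outer aromatic ring; the recorded stereochemical step gives no guide to a methyl-for-hydrogen exchange, and the values of compounds 1 and 3 show only that the inverted ring carbons are the stronger series. With nothing pointing either way, the expectation for compound 4 is a step of a 1.1-fold lower number from compound 2 to compound 4 (0.05 log units; within the scatter) in this assay, that is, no movement beyond the usual scatter from the number of compound 2. Compound 4 is therefore estimated at 3800 nM, with a range from 1200 nM to 12000 nM, in this assay.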

Compound 4, half-maximal inhibitory concentration: 580 nM
The estimate for compound 4 lay 6.6-fold (0.82 log units) above the measured number; measured number below the stated range.
By their numbers in this assay, from the lowest: compound 3; then compound 1; then compound 4; then compound 2.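

The outer aromatic ring is not a silent position: in this assay, phenyl to 4-methylphenyl gives a 7.4-fold lower number from compound 2 to compound 4 (0.87 log units; beyond the scatter), so a single methyl, para to a large group on an aromatic carbon of this ring, moves the number beyond the scatter. Going by these compounds alone, until now the only readable step was the change in drawn configuration at the saturated ring carbons, a 46-fold lower number from compound 2 to compound 3 (1.66 log units; beyond the scatter), and the series now has a second place where one change shifts inhibition, here within the ring configuration of compound 2. No recorded evidence bears on why a methyl at this position gives stronger inhibition, and the step stands as an observation only.

Whether the methyl gives a similar step in the ring configuration of compound 3 stays open, since that pair is not among the compounds shown, and compound 1 differs from compound 3 in more than one place and cannot stand in for it. Also open, from the compounds shown here alone, is whether the step belongs to methyl alone or extends to other groups at the same position, such as methoxy, chlorine or a carboxylic acid.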